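Swapping the Fluorinated Ring on Compound 1

A few compounds are considered here, and "the series" means these few. Any claim that something is new, unique, unknown or untested is made for them only; others in the source may bear on it.

Measured in an ADME assay on MT4 cells (Homo sapiens) for cytotoxicity, read by MTT assay, with a stated time of 96 h; a higher number here means that more compound is tolerated, a lower number that less compound is tolerated:
- Compound 1 `Fc1ccc(F)c(/N=N/c2ccc(NC[C@@H]3CCCN4CCCC[C@H]34)c3c2CCCC3)c1`: 40000 nM
- Compound 2 `CN1CCN(/N=N/c2ccccc2)CC1`: 65000 nM
- Compound 3 `CN(C)CCCNc1ccc(/N=N/c2ccccc2)cc1`: 17000 nM

Compound 1 cannot be told apart from compound 2, since their numbers lie within the usual scatter, while its number stands beyond the scatter over that of compound 3. Compound 4 `FC(F)(F)c1cccc(/N=N/c2ccc(NC[C@@H]3CCCN4CCCC[C@H]34)c3c2CCCC3)c1` keeps the core of compound 1 but carries 3-(trifluoromethyl)phenyl in place of 2,5-difluorophenyl on a double-bonded nitrogen. Among the measured compounds shown here, no measured pair shows this swap, so the expectation rests on compound 1 alone, at 40000 nM. No step beyond the scatter is expected in this assay. The estimated step is a 1.3-fold lower number from compound 1 to compound 4 (0.10 log units; within the scatter). Compound 4 is estimated at 32000 nM, with an expected range of 13000 nM to 75000 nM.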

Compound 4, half-maximal cytotoxic concentration: 15000 nM
Compound 4: middle estimate off by 2.1-fold (0.33 log units), on the high side, and the stated range covers the measured number.
By their numbers in this assay, from the lowest: compounds 4 and 3 (each within the scatter of the next); then compounds 1 and 2 (each within the scatter of the next).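

In this assay putting 3-(trifluoromethyl)phenyl in place of 2,5-difluorophenyl on a double-bonded nitrogen gives a 2.7-fold lower number from compound 1 to compound 4 (0.43 log units; beyond the scatter) and so shows that a swap at this position alone can move the number beyond the scatter while the core of compound 1 stays the same. The earlier compounds shown here could not show this, as no two of them differed in one place. Nothing available explains the size of this step.

Still open, from the compounds shown here alone, is whether the trifluoromethyl group or the loss of the two fluorines matters more, and what a methoxy group or a carboxylic acid on that ring would give.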